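Working notes: compound 1 to compound 3

The source may report more compounds than this note shows. Statements on the series, on what has been measured and on what is new or still open speak of the compounds shown alone.

Measured so far:
- compound 1 `Nc1cc(-c2cccc(-n3ccc4cc(C5CC5)cc(F)c4c3=O)c2CO)nc(Nc2cnn(C3(CO)CC3)c2)n1`: 0.7 10^-6 cm/s
- compound 2 `Cn1cc(Nc2nc(N)cc(-c3cccc(-n4ccc5cc(C6CC6)cc(F)c5c4=O)c3CO)n2)cn1`: 6.3 10^-6 cm/s

In an ADME assay on Caco-2 cells (Homo sapiens) for permeability (a higher number here means that the compound crosses the layer faster, a lower number that the compound crosses the layer more slowly), compound 1 stands lowest of the two measured compounds, at 0.7 10^-6 cm/s. Compound 3 `CCn1cc(Nc2nc(N)cc(-c3cccc(-n4ccc5cc(C6CC6)cc(F)c5c4=O)c3CO)n2)cn1` has not been measured yet. It differs from compound 1 in one place: ethyl in place of 1-(hydroxymethyl)cyclopropyl on an aromatic nitrogen. Put briefly, this is ethyl in place of 1-(hydroxymethyl)cyclopropyl on an aromatic nitrogen.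

Among the measured compounds shown here, one measured step bears on this change. It removes the same group from the same place, with methyl entering instead: a 9.0-fold higher number from compound 1 to compound 2 (0.95 log units; beyond the scatter). That step lies beyond the scatter. For the measured compounds named here, no measured compound carries ethyl, so how far the methyl result transfers remains untested. Even so, a step of similar size towards a higher number is expected in this assay, resting on compound 2 at 6.3 10^-6 cm/s. The estimated step is an 8.6-fold higher number from compound 1 to compound 3 (0.93 log units; beyond the scatter). For compound 3 the estimated value is 6 10^-6 cm/s, with an expected range of 2.5 10^-6 cm/s to 13 10^-6 cm/s.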

Compound 3, apparent permeability: 5.4 10^-6 cm/s
Compound 3: middle estimate off by 1.1-fold (0.05 log units), on the high side, and the stated range covers the measured number.
By their numbers in this assay, from the lowest: compound 1; then compounds 3 and 2 (each within the scatter of the next).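

In this assay ethyl on this aromatic nitrogen gives a 7.7-fold higher number from compound 1 to compound 3 (0.89 log units; beyond the scatter) and so repeats what methyl showed, which means the step away from 1-(hydroxymethyl)cyclopropyl no longer rests on a single replacement group. Lengthening the substituent from methyl to ethyl gives a 1.2-fold lower number from compound 2 to compound 3 (0.07 log units; within the scatter) and does not separate the two groups, so across these compounds the size of the step does not depend on which of the two small alkyl groups enters. Nothing measured on these compounds accounts for the step from 1-(hydroxymethyl)cyclopropyl to either alkyl group.

The group that leaves differs from ethyl and methyl at once in its three-membered ring, its hydrogen-bond donor and acceptor, and its heavy-atom count, and the compounds shown do not tell these apart. On these data alone, a plain cyclopropyl or a 2-hydroxyethyl on the same nitrogen would separate the ring from the hydroxyl, and how a longer chain or a chain ending in an amine would read in this assay remains open.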